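The source may hold more compounds than are shown below. What is called first, only, known or untested is meant among the compounds shown, and "the series" means these compounds.

Measured so far:
- compound 1 `CC(C)CCc1c(OCCCCCCCC(=O)NO)ccc2ccc(=O)oc12`: 3580 nM
- compound 2 `CC(C)CCc1c(OCCCCC(=O)NO)ccc2ccc(=O)oc12`: 1310 nM
- compound 3 `CC(C)CCc1c(OCCCCC(=O)NO)ccc2c1OC(=O)CC2`: a limit only, > 30000 nM

All three were tested in a functional assay on Hep 3B2 cells (Homo sapiens) for antiproliferative activity, read by sulforhodamine B assay, with a stated time of 48 h; on this read-out lower numbers stand for stronger inhibition of growth and higher numbers for weaker inhibition of growth. Compound 2 gives 1310 nM, while compound 1 gives 3580 nM. The two differ by 3-(hydroxycarbamoyl)propyl in place of hydroxycarbamoyl on a saturated chain carbon, four bonds along the chain from an oxygen on an aromatic ring, and this change produced a 2.7-fold higher number from compound 2 to compound 1 (0.44 log units; beyond the scatter), so the longer chain weakened growth inhibition somewhat.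

Compound 3 carries the shorter chain of compound 2 on another core; the difference between the two cores is not broken down here. For compound 3 this assay reports only a limit, > 30000 nM, which is the limit of > 30000 nM in this assay, at which 1 of the 3 values shown sits.

Compound 4 `CC(C)CCc1c(OCCCCCCCC(=O)NO)ccc2c1OC(=O)CC2` has not been measured. It differs from compound 3 by 3-(hydroxycarbamoyl)propyl in place of hydroxycarbamoyl on a saturated chain carbon, four bonds along the chain from an oxygen on an aromatic ring, the same change that separates compound 2 from compound 1. From compound 3 to compound 4 the expected step is a step that the limit leaves unreadable from compound 3 to compound 4, in the same direction as before, because the measured pair showed a 2.7-fold higher number from compound 2 to compound 1 (0.44 log units; beyond the scatter). Compound 4 is therefore expected to give about 60000 nM, somewhere between 20000 nM and 200000 nM, and most likely this assay will again report only a limit.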

Compound 4, concentration for 50% growth inhibition: > 30000 nM
Compound 4 was reported as a limit; the forecaster's own chance of this, stated with the estimate: 85%; the middle value does not contradict the limit.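

In this assay compound 4 gives > 30000 nM, which is a limit and not a number. Compound 3 also gives only a limit, > 30000 nM. Within the data shown here, no step between compound 3 and compound 4 can therefore be read. From the compounds shown here alone, it remains open whether the longer chain weakens growth inhibition on the core of compound 3 as it does on the core of compound 2.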